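Lipophilicity of a carbamate analogue of compound 3

A few compounds are considered here, and "the series" means these few. Any claim that something is new, unique, unknown or untested is made for them only; others in the source may bear on it.

Compound 1 `Cc1cc(C(=O)Nc2c(F)cccc2F)nn1Cc1cc(Cl)ccc1OCc1ccccc1`: in a physicochemical assay for lipophilicity, at pH 7.4 (on this read-out higher numbers stand for higher lipophilicity and lower numbers for lower lipophilicity), compound 1 gives 3.7.
Compound 2 `Cc1cc(C(=O)NCc2cccnc2)nn1Cc1cc(Cl)ccc1OCc1ccccc1`: in this assay compound 2 gives > 3.7, which is a limit of the assay and not a number.
Compound 3 `Cc1cc(NC(=O)C(C)C)nn1Cc1cc(Cl)ccc1OCc1ccccc1`: in this assay compound 3 gives > 3.7, again a limit of the assay and not a number.

Compound 3 therefore stands at the top of what this assay reports, as does compound 2 (the limit of > 3.7 in this assay, at which 2 of the 3 values shown sit). As far as these compounds go, the measured steps into compound 3 are a number no lower from compound 1 to compound 3 (the limit leaves the size open) and a step that the two limits leave unreadable from compound 2 to compound 3, and the step of a number no lower from compound 1 to compound 2 (the limit leaves the size open) is also open in size; none of them gives a readable number. Compound 4 `Cc1cc(NC(=O)OCc2ccccn2)nn1Cc1cc(Cl)ccc1OCc1ccccc1` differs from compound 3 by (pyridin-2-yl)methoxy in place of isopropyl on a carbonyl carbon. Among the measured compounds shown here, no measured step covers this change, and the only anchor is that compound 3 sits at the limit. Compound 4 is expected to read about 3.6, somewhere between 3 and 4.2. The expected step of a number at least 0.10 log units lower from compound 3 to compound 4 (that floor lies within the scatter) is an estimate that rests on the limit alone, and a further limit for compound 4 would not be surprising.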

Compound 4, distribution coefficient: 3.1
The estimate for compound 4 lay 0.50 log units above the measured number; the range from low to high includes it.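

At the carbonyl carbon whose other neighbour is an amide-type nitrogen, (pyridin-2-yl)methoxy in place of isopropyl gives a change that can be seen in this assay, as a number at least 0.60 log units lower from compound 3 to compound 4 (beyond the scatter). The same carbamate also shows a number at least 0.60 log units lower from compound 2 to compound 4 (beyond the scatter) and a number 0.60 log units lower from compound 1 to compound 4 (beyond the scatter), so it reads lowest of the four, and only the last of these steps has a readable size. The other two steps are floors and not sizes because compound 2 and compound 3 each stand at a limit of the assay and not at a number: the limit of > 3.7 in this assay, at which 2 of the 4 values shown sit.

The steps among compound 1, compound 2 and compound 3 still cannot be read. What a benzyloxy or a plain methoxy would read on that carbonyl carbon stays open, so the compounds shown do not separate the share of the pyridine nitrogen from that of the carbamate oxygen.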